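A few compounds are considered here, and "the series" means these few. Any claim that something is new, unique, unknown or untested is made for them only; others in the source may bear on it.

Values in a functional assay on SGC-7901 cells (Homo sapiens) for cytotoxicity, read by MTT assay, with a stated time of 38 h (a higher number here means a weaker inhibitor, a lower number a stronger inhibitor), for the measured compounds:

Compound 1 (`COc1cc(OC)c2c(=O)c(OCC(=O)N/N=C/c3ccc(C)cc3)c(-c3cc(OC)c(OC)c(OC)c3)oc2c1`): 10100 nM
Compound 2 (`COc1cc(OC)c2c(=O)c(OCCCCN3CCCCC3)c(-c3cc(OC)c(OC)c(OC)c3)oc2c1`): 6080 nM
Compound 3 (`COc1cc(OC)c2c(=O)c(OCC(=O)N/N=C/c3ccco3)c(-c3cc(OC)c(OC)c(OC)c3)oc2c1`): 5720 nM

These three values form a single band, and compound 3 stands inside it with the other two. The step of a 1.8-fold lower number from compound 1 to compound 3 (0.25 log units; within the scatter) and the step of a 1.1-fold lower number from compound 2 to compound 3 (0.03 log units; within the scatter) separate it from them by no more than the ordinary spread of repeat measurements.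

Compound 4 (`CCN(CC)CCCOc1c(-c2cc(OC)c(OC)c(OC)c2)oc2cc(OC)cc(OC)c2c1=O`) keeps the shared core of compound 3 and differs in one place. The change is a group of 7 heavy atoms (6 carbon, 1 nitrogen; no ring) in place of a group of 10 heavy atoms (6 carbon, 2 nitrogen, 2 oxygen; one five-membered aromatic ring with 1 hetero atom), on a saturated chain carbon bound to an oxygen on an aromatic ring and the group that enters is 2-(diethylamino)ethyl. For the measured compounds named here, no measured compound carries that group, so the evidence is indirect.

Two measured steps are exchanges at this same place. One is the step of a 1.7-fold lower number from compound 1 to compound 2 (0.22 log units; within the scatter) and the other is the step of a 1.1-fold lower number from compound 2 to compound 3 (0.03 log units; within the scatter) again. In compound 2, as in compound 4, the group there has no aromatic ring. Neither exchange moved the number beyond the scatter, and a step of similar size is expected here, with no direction favoured. The estimated change is a 1.0-fold higher number from compound 3 to compound 4 (0.02 log units; within the scatter) and so nothing beyond the scatter is expected in this assay. Compound 4 is therefore expected at 6000 nM, with an estimated range of 2500 nM to 14000 nM.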

Compound 4, half-maximal inhibitory concentration: 56900 nM
Compound 4: middle estimate off by 9.5-fold (0.98 log units), on the low side; the measured number lies above the stated range.
By their numbers in this assay, from the lowest: compounds 3, 2 and 1 (each within the scatter of the next); then compound 4.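

In this assay, this position no longer looks indifferent to exchange: putting in 2-(diethylamino)ethyl gives a clear loss of activity against both compounds that carry the longer aromatic-ring groups (a 9.9-fold higher number from compound 3 to compound 4 (1.00 log units; beyond the scatter) and a 5.6-fold higher number from compound 1 to compound 4 (0.75 log units; beyond the scatter)), and compound 4 is the weakest of the four. The most telling comparison is with compound 2, whose group also has no aromatic ring, yet the exchange of diethylamino in place of (piperidin-1-yl)methyl on the saturated chain carbon still gives a step beyond the scatter (a 9.4-fold higher number from compound 2 to compound 4 (0.97 log units; beyond the scatter)), so compound 2 goes against any reading in which the loss of the aromatic ring alone accompanies the higher number. No measurement offered here accounts for this difference.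

The compounds shown leave open whether the higher number belongs to the diethylamino group in particular or would also appear with a pyrrolidin-1-yl or morpholin-4-yl group on the same chain. They also leave open whether a dimethylamino group, closer in form to diethylamino but smaller, would stay with compound 2 and compound 3 or with compound 4.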